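Propylamino in Place of 3-Methylpiperazin-1-yl: Predicting Compound 4

The source may report more compounds than this note shows. Statements on the series, on what has been measured and on what is new or still open speak of the compounds shown alone.

Of the compounds shown here, three have so far been tested in a functional assay on SW480 cells (Homo sapiens) for inhibition, read by luminescence and resazurin assay, with a stated time of 3 days; a higher number here means a weaker inhibitor, a lower number a stronger inhibitor. Compound 1 `CCCNc1nc(NCc2ccc(C(=O)NCc3ccc(F)cc3)cc2)c2cc(C)ccc2n1` gives 2200 nM. Compound 2 `Cc1ccc2nc(N3CCNC(C)C3)nc(NCc3ccc(C(=O)NCc4ccc(F)cc4)cc3)c2c1` gives 1400 nM. Compound 3 `Cc1ccc2nc(N3CCNC(C)C3)nc(NCc3ccc(C(=O)NC4CCN(Cc5ccc(F)cc5)CC4)cc3)c2c1` gives 1000 nM, the lowest of the three numbers; its gap to compound 2 lies within the scatter of this kind of measurement, while its gap to compound 1 lies beyond it.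

Compound 2 and compound 1 differ in a single place: propylamino in place of 3-methylpiperazin-1-yl on an aromatic carbon. That change produced a 1.6-fold higher number from compound 2 to compound 1 (0.20 log units; within the scatter), a step too small to count as a real shift.

Compound 4 `CCCNc1nc(NCc2ccc(C(=O)NC3CCN(Cc4ccc(F)cc4)CC3)cc2)c2cc(C)ccc2n1` has not yet been measured. It arises from compound 3 by the same kind of change, (propylamino in place of 3-methylpiperazin-1-yl on an aromatic carbon), and the surroundings of the place are described in exactly the same words as before. How the core of compound 3 differs from that of compound 2 is not broken down here; the two simply differ by a larger part of the molecule.

A small step is expected here, a 1.6-fold higher number from compound 3 to compound 4 (0.20 log units; within the scatter), because the same change earlier gave a 1.6-fold higher number from compound 2 to compound 1 (0.20 log units; within the scatter). In this assay compound 4 is therefore expected to give 1600 nM. Compound 4 is estimated to fall between 800 nM and 3500 nM, with only a slim chance that the assay returns a limit rather than a number.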

Compound 4, half-maximal inhibitory concentration: 1100 nM
Beside the measured number, compound 4's estimate is 1.5-fold (0.16 log units) above it; low and high end bracket the measured number.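

In this assay the swap of 3-methylpiperazin-1-yl for propylamino on the core of compound 3 gives a 1.1-fold higher number from compound 3 to compound 4 (0.04 log units; within the scatter) and so, as on the core of compound 2, produces no real shift. This shows that a step too small to count carried over from one core to the other, so on these two cores the propylamino and 3-methylpiperazin-1-yl groups can be exchanged in this measurement without a visible penalty, but it does not show that the change would behave alike on a core outside this pair, in another test, or in any case where the step turned out large, and two pairs are too few to call it a rule for the series. Set side by side, the two steps agree: the same change on two cores in this assay, a 1.6-fold higher number (0.20 log units; within the scatter) from compound 2 to compound 1 and a 1.1-fold higher number (0.04 log units; within the scatter) from compound 3 to compound 4, 1.4-fold (0.15 log units) apart, within the scatter of two such steps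

The compounds shown leave open whether the same place would tolerate other groups just as well, such as a longer chain like butylamino, a morpholin-4-yl ring or an unsubstituted piperazin-1-yl ring. They also leave open whether any group on this aromatic carbon can move the number by more than the scatter on either core.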